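The compounds below may be only part of what the source reports. "The series", "measured", "known", "first", "only" and "open" are said of these compounds alone.

Compound 1 `COc1ccc(C2=NN(C(=O)c3cncc(Br)c3)C(c3ccc(OC)cc3)C2)cc1` and compound 2 `COc1ccc(C2=NN(C(=O)c3ccc(Cl)nc3)C(c3ccc(OC)cc3)C2)cc1` share one core, while compound 3 `O=C(c1cncc(Br)c1)N1N=C(c2ccc(Cl)cc2)CC1c1ccc(Cl)cc1` and compound 4 `O=C(c1ccc(Cl)nc1)N1N=C(c2ccc(Cl)cc2)CC1c1ccc(Cl)cc1` share another; how the two cores differ is not broken down here. In a functional assay on WM 266-4 cells (Homo sapiens) for antiproliferative activity, read by MTT assay, with a stated time of 24 h (a lower number here means a stronger inhibitor of growth, a higher number a weaker inhibitor of growth), compound 1 gives 7560 nM, and compound 2 gives 6450 nM. Compound 3 gives 6090 nM in this assay, and its values stand within the scatter of the other two measured compounds, so no order among them can be claimed.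

The change from compound 1 to compound 2 is 6-chloropyridin-3-yl in place of 5-bromopyridin-3-yl on a carbonyl carbon, and it made a step of a 1.2-fold lower number from compound 1 to compound 2 (0.07 log units; within the scatter). The change from compound 3 to compound 4 is 6-chloropyridin-3-yl in place of 5-bromopyridin-3-yl on a carbonyl carbon, and it is the same change, made at the same kind of place, on the other core.

Compound 4 has not been measured in this assay. For the measured compounds named here, because the only measured instance of this change gave a 1.2-fold lower number from compound 1 to compound 2 (0.07 log units; within the scatter), the step from compound 3 to compound 4 is expected to be a 1.1-fold lower number from compound 3 to compound 4 (0.06 log units; within the scatter), with little to separate the two. Compound 4 is therefore estimated to give 5300 nM, between 2800 nM and 10000 nM.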

Compound 4, concentration for 50% growth inhibition: 9890 nM
Beside the measured number, compound 4's estimate is 1.9-fold (0.27 log units) below it; the range from low to high includes it.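

On the core of compound 3, the swap to 6-chloropyridin-3-yl in this assay gave a 1.6-fold higher number from compound 3 to compound 4 (0.21 log units; within the scatter). Set beside the earlier instance, the step does not differ from it by more than the measurements can resolve: the same change on two cores in this assay, a 1.2-fold lower number (0.07 log units; within the scatter) from compound 1 to compound 2 and a 1.6-fold higher number (0.21 log units; within the scatter) from compound 3 to compound 4, 1.9-fold (0.28 log units) apart, within the scatter of two such steps. This shows that the change stayed within the scatter on both cores and gave no sign of behaving differently on one of them, but it does not show that the change carries over with a fixed size or direction, as two steps this small, one to a lower number and one to a higher number, can establish neither.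

The compounds shown leave open whether any group on this carbonyl carbon could move the number beyond the scatter, as both groups shown are halogen-bearing pyridinyl rings. A pyridine carrying an amine or a carboxylic acid in place of the halogen, measured on both cores, would test whether a larger step carries over from one core to the other.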